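Sulfamoylurea series: aryl amide exchange, rat blood activity

A few compounds are considered here, and "the series" means these few. Any claim that something is new, unique, unknown or untested is made for them only; others in the source may bear on it.

Notes on the series. Compound 1 `Cc1ncsc1C(=O)NCCC1CCN(S(=O)(=O)NC(=O)NC[C@@H]2C[C@@H]3C=C[C@@H]2C3)CC1` is the reference structure here. In a functional assay on the whole organism (blood) with Rattus norvegicus as the target, with stated times of 24 h and 1 h, at a dose of 15 mg/kg by the intraperitoneal route (on this read-out lower numbers stand for a weaker effect and higher numbers for a stronger effect at the one dose given), compound 1 gives 25%. Going by the values given here, the only other measured member, compound 2 `COc1ncccc1C(=O)NCCC1CCN(S(=O)(=O)NC(=O)NC2CCCCC2)CC1`, gives 35% in this assay, a number that lies within the usual scatter of that of compound 1, so the two cannot be told apart on these data; compound 2 also differs from compound 1 in more than one place, so no single step can be read from that pair.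

Compound 3 `O=C(NC[C@@H]1C[C@@H]2C=C[C@@H]1C2)NS(=O)(=O)N1CCC(CCNC(=O)c2cnccc2Cl)CC1` is not yet measured. It differs from compound 1 in one place: 4-chloropyridin-3-yl in place of 4-methyl-1,3-thiazol-5-yl on a carbonyl carbon. Among the compounds with values here, no measured pair shows this change, so nothing in the data supports a step beyond the scatter. The step from compound 1 to compound 3 in this assay is therefore expected to be no change at the digits printed from compound 1 to compound 3 (within the scatter), that is, none beyond the scatter. Compound 3 is estimated at 25% in this assay, with a range from 10% to 42%.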

Compound 3, a percentage reported as activity, at one dose (the size of the read-out at that dose, not a potency): 12%
Beside the measured number, compound 3's estimate is 13 percentage points above it, within the range that was stated.
By their numbers in this assay, from the lowest: compound 3; then compounds 1 and 2 (each within the scatter of the next).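

In this assay, the exchange of 4-methyl-1,3-thiazol-5-yl for 4-chloropyridin-3-yl on a carbonyl carbon gives a number 13 percentage points lower from compound 1 to compound 3 (beyond the scatter), the first single-place step readable in the series. With the rest of compound 1 held constant, this position therefore has a measurable effect on the read-out, and this change lowers it modestly. No available evidence bears on the cause of the step, and the ring size, hetero atoms and chlorine remain unseparated as possible contributors.

The compounds shown leave open whether the step follows the chlorine or the pyridine ring, which an unsubstituted pyridin-3-yl or a 4-chlorophenyl on the same carbonyl carbon would help separate. From the compounds shown here alone, it also remains open whether the same exchange gives a similar step on the core of compound 2.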